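The compounds below may be only part of what the source reports. "The series", "measured", "known", "first", "only" and "open" are said of these compounds alone.

Measured so far:
compound 1 `CCn1ncc2c(F)cc(-c3ccc(C(CC)(CC)c4nnc(C)[nH]4)c(=O)[nH]3)cc21` – 34 nM
compound 2 `CC(C)C(c1ccc(-c2ccc3cccc(F)c3c2)[nH]c1=O)N1CCN/C1=N\C#N` – 23 nM

Of the compounds shown here, two have been measured in an assay on CHO cells for displacement of a labelled ligand from prostaglandin E2 receptor EP3 subtype (Homo sapiens), read by radioligand binding; on this read-out lower numbers stand for stronger inhibition and higher numbers for weaker inhibition. Compound 1 `CCn1ncc2c(F)cc(-c3ccc(C(CC)(CC)c4nnc(C)[nH]4)c(=O)[nH]3)cc21` gives 34 nM and compound 2 `CC(C)C(c1ccc(-c2ccc3cccc(F)c3c2)[nH]c1=O)N1CCN/C1=N\C#N` gives 23 nM. The two numbers sit close together, and their gap is within the usual scatter of repeated measurements, so neither compound can be called the stronger binder. Compound 3 `CC(C)C(Cc1nnc[nH]1)c1ccc(-c2ccc3cccc(F)c3c2)[nH]c1=O` has not yet been measured. It differs from compound 2 in one place: a group of 6 heavy atoms (3 carbon, 3 nitrogen; one five-membered aromatic ring with 3 hetero atoms) in place of a group of 8 heavy atoms (4 carbon, 4 nitrogen; one five-membered non-aromatic ring with 2 hetero atoms), on a saturated chain carbon bound to an aromatic carbon and a saturated chain carbon. Among the compounds with values here, no measured pair shows the effect of this change, so the expectation rests only on the shared core and on the small spread of the two measured numbers. The expected step is a modest one, a 1.7-fold higher number from compound 2 to compound 3 (0.24 log units; within the scatter), toward a somewhat weaker number, and it may well stay within the scatter. Compound 3 is therefore estimated to give 40 nM in this assay, with a range from 10 nM to 160 nM.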

Compound 3, inhibition constant: 10 nM
For compound 3 the middle estimate is 4.0-fold (0.60 log units) above the measured one; low and high end bracket the measured number.
By their numbers in this assay, from the lowest: compound 3; then compounds 2 and 1 (each within the scatter of the next).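

In this assay, putting (4H-1,2,4-triazol-3-yl)methyl in place of the five-membered non-aromatic ring group, on a saturated chain carbon bound to an aromatic carbon and a saturated chain carbon, gives a 2.3-fold lower number from compound 2 to compound 3 (0.36 log units; beyond the scatter) and so a real gain in binding. This position therefore responds to the choice of group, and the double and triple bonds outside aromatic rings in the group that leaves are not needed for strong binding. Both groups count the same hydrogen-bond donors and acceptors, so these counts do not separate them, and no measurement at hand says why the number falls.

The compounds shown leave open whether the aromatic ring itself or its one-carbon link matters more. They also leave open how a carboxylic acid or an amine would fare at this place.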